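Oxetanyl amide to morpholine amide on a shared core

The compounds below may be only part of what the source reports. "The series", "measured", "known", "first", "only" and "open" are said of these compounds alone.

Three measured compounds share one core: compound 1 `CCN(CC)S(=O)(=O)c1ccc(S(=O)(=O)N2CCC[C@@H](C(=O)N[C@H]3CC[C@H](OC)CC3)C2)cc1`, compound 2 `CCN(CC)S(=O)(=O)c1ccc(S(=O)(=O)N2CCC[C@@H](C(=O)N3CCC(OC)CC3)C2)cc1` and compound 3 `CCN(CC)S(=O)(=O)c1ccc(S(=O)(=O)N2CCC[C@@H](C(=O)NC3COC3)C2)cc1`. In a functional assay on MIA PaCa-2 cells (Homo sapiens) for inhibition, read by MTT assay, with a stated time of 7 days (a lower number here means a stronger inhibitor, a higher number a weaker inhibitor), compound 1 gives 1350 nM, compound 2 gives 140 nM, and compound 3 gives 2340 nM. Compound 3 thus holds the highest number of the three; its gap to compound 1 lies within the scatter, while a 17-fold higher number from compound 2 to compound 3 (1.22 log units; beyond the scatter) is a large step.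

The next compound, compound 4 `CCN(CC)S(=O)(=O)c1ccc(S(=O)(=O)N2CCC[C@@H](C(=O)N3CCOCC3)C2)cc1`, alters the carbonyl substituent once more: morpholin-4-yl in place of (oxetan-3-yl)amino on a carbonyl carbon. Among the measured compounds shown here, two measured steps bear on this change. a 9.6-fold lower number from compound 1 to compound 2 (0.98 log units; beyond the scatter) shows that replacing an amino-linked ring with a nitrogen-linked saturated ring on the carbonyl carbon brought a clearly lower number, and a 17-fold higher number from compound 2 to compound 3 (1.22 log units; beyond the scatter) shows the reverse direction, back to an amino-linked ring, raising the number strongly. Compound 4 follows the first of these directions, so a lower number in this assay is expected, although nothing in the data shows how closely a morpholin-4-yl ring tracks 4-methoxypiperidin-1-yl in this position. Compound 4 is therefore estimated at 300 nM, within a range from 100 nM to 1000 nM, which means the expected step of a 7.8-fold lower number from compound 3 to compound 4 (0.89 log units; beyond the scatter) would lie beyond the scatter.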

Compound 4, half-maximal inhibitory concentration: 350 nM
Compound 4: middle estimate off by 1.2-fold (0.07 log units), on the low side; measured number inside the range.
By their numbers in this assay, from the lowest: compound 2; then compound 4; then compounds 1 and 3 (each within the scatter of the next).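

In this assay, morpholin-4-yl on the carbonyl carbon gives a lower number than either amino-linked ring, with a 6.7-fold lower number from compound 3 to compound 4 (0.83 log units; beyond the scatter) and a 3.9-fold lower number from compound 1 to compound 4 (0.59 log units; beyond the scatter), so the drop seen earlier with 4-methoxypiperidin-1-yl is not confined to that one group: among these four compounds, both rings joined through their own nitrogen stand lower than both amino-linked rings, and none goes against this. The two nitrogen-linked rings are not equivalent, however, since a 2.5-fold higher number from compound 2 to compound 4 (0.40 log units; beyond the scatter) shows that the choice of ring still matters once the amide hydrogen is gone. No measurement shown here accounts for these differences in the number.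

In every step shown, the change from an amino link to a nitrogen-linked ring comes with a change in the ring itself, so the contribution of each remains open. A simple piperidin-1-yl group, or an open-chain dimethylamino group, on the same carbonyl carbon would help show whether the ring, its oxygen or the link alone sets the number.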